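Butyl for cyclohexyl: working notes on compound 3

This account rests on a few compounds, and the source may have more. Where it says the series, first, only, none or still open, it means among the compounds named here.

Measured in a functional assay on HT-29 cells (Homo sapiens) for antiproliferative activity, read by sulforhodamine B assay, with a stated time of 48 h; on this read-out lower numbers stand for stronger inhibition and higher numbers for weaker inhibition:
- compound 1 `O=C1NCCN1c1ccc(S(=O)(=O)Nc2ccc3[nH]ccc3c2)cc1`: 130 nM
- compound 2 `O=C1NCCN1c1ccc(S(=O)(=O)Nc2ccc(C3CCCCC3)cc2)cc1`: > 1000 nM

Compound 2 stands at > 1000 nM, which is a limit of this assay and not a number. Compound 3 `CCCCc1ccc(NS(=O)(=O)c2ccc(N3CCNC3=O)cc2)cc1` has butyl in place of cyclohexyl on an aromatic carbon, para to a large group: butyl in place of cyclohexyl on an aromatic carbon. Within the data shown here, no measured step covers this kind of change. Only a small move in this assay is expected, with no clear direction and no recovery towards compound 1. The expected step is a step that the limit leaves unreadable from compound 2 to compound 3. Compound 3 is estimated at 1500 nM, with an expected range of 400 nM to 6000 nM.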

Compound 3, half-maximal inhibitory concentration: 610 nM
For compound 3 the middle estimate is 2.5-fold (0.39 log units) above the measured one, and the stated range covers the measured number.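

At this position, on an aromatic carbon para to a large group, butyl brings a readable value into this assay: compound 3 gives 610 nM. Compound 2 stands at > 1000 nM, which is a limit and not a number. The change reads as an at least 1.6-fold lower number from compound 2 to compound 3 (0.21 log units; that floor lies within the scatter), and this is only a floor, with the full size of the step unreadable because of the limit: the limit of > 1000 nM in this assay, at which 1 of the 3 values shown sits.

Open, going by these compounds, is whether a longer chain, an amine or a carboxylic acid in place of butyl at this position would give a lower number in this assay.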